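Aryl swap at the saturated ring carbon of compound 3

The source may hold more compounds than are shown below. What is called first, only, known or untested is meant among the compounds shown, and "the series" means these compounds.

In a functional assay on OVCAR cells (Homo sapiens) for cytotoxicity, read by sulforhodamine B assay, with a stated time of 48 h (a lower number here means a stronger inhibitor, a higher number a weaker inhibitor), compound 3 `O=CCN1N=C(c2ccc3ccccc3c2)CC1c1cccc([N+](=O)[O-])c1` gives 3390 nM, the lowest of the three numbers recorded so far. Compound 2 `CC(=O)N1N=C(c2cccc3ccccc23)CC1c1ccccc1` gives 7820 nM and compound 1 `COc1ccc(C2CC(c3cccc([N+](=O)[O-])c3)=NN2C(C)=O)cc1` gives 8760 nM in this assay; both gaps to compound 3 lie beyond the scatter, so compound 3 is the strongest inhibitor of the three. No two of these compounds differ in one place only, so no single-point step can be read from the measured set.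

Compound 4 `COc1ccc(C2CC(c3ccc4ccccc4c3)=NN2CC=O)cc1` differs from compound 3 in one place: 4-methoxyphenyl in place of 3-nitrophenyl on a saturated ring carbon. Going by the values given here, the only other compound carrying 4-methoxyphenyl is compound 1, and it differs from compound 3 in more than one place, so its number cannot be taken as the effect of this change alone. The step is expected to be small and towards a weaker inhibitor, and it may not exceed the scatter; a 1.5-fold higher number from compound 3 to compound 4 (0.17 log units; within the scatter) is the expected step. Compound 4 is estimated at 5000 nM, in the range 2000 nM to 12000 nM in this assay.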

Compound 4, half-maximal inhibitory concentration: 5790 nM
The estimate for compound 4 lay 1.2-fold (0.06 log units) below the measured number; the range from low to high includes it.
By their numbers in this assay, from the lowest: compounds 3, 4, 2 and 1 (each within the scatter of the next, the first and the last beyond it).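

Going by these compounds alone, replacing 3-nitrophenyl with 4-methoxyphenyl on the saturated ring carbon gives a 1.7-fold higher number from compound 3 to compound 4 (0.23 log units; within the scatter) in this assay, the first step that isolates a single change. At this position, on the core shared by compound 3 and compound 4, the read-out does not separate the two aryl groups. The 3-nitrophenyl group is therefore not required here for a number in this range, although this rests on one pair only. No measurement available here explains the result.

As far as these compounds go, whether an aminophenyl or carboxylic acid-bearing phenyl group at this carbon would also stay within the scatter remains open. Steps linking compound 1 or compound 2 to the others cannot be read, so the contribution of the other positions also remains open.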